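Compound 3: Phenylethenyl in Place of 2-Chlorophenyl

The source may report more compounds than this note shows. Statements on the series, on what has been measured and on what is new or still open speak of the compounds shown alone.

For the measured compounds named here, compound 2 `Cc1cc(O)c(C2=NN(c3ccc(S(N)(=O)=O)cc3)C(c3ccccc3Cl)C2)cc1Cl` is one of two compounds measured so far in a functional assay on HT-29 cells (Homo sapiens) for antiproliferative activity, with a stated time of 48 h; a lower number here means that less compound is tolerated, a higher number that more compound is tolerated; in it compound 2 gives 6830 nM, the lowest of the two numbers, while compound 1 `Cc1cc(O)c(C2=NN(c3ccc(S(N)(=O)=O)cc3)C(c3ccccc3O)C2)cc1Cl` gives 12900 nM, a step of a 1.9-fold lower number from compound 1 to compound 2 (0.28 log units; within the scatter) that stays within the scatter. Compound 3 `Cc1cc(O)c(C2=NN(c3ccc(S(N)(=O)=O)cc3)C(/C=C/c3ccccc3)C2)cc1Cl` differs from compound 2 by 2-phenylethenyl in place of 2-chlorophenyl on a saturated ring carbon. Going by the values given here, no measured step covers this change, and the single known step was within the scatter, so the expected change in this assay from compound 2 to compound 3 is a 1.0-fold higher number from compound 2 to compound 3 (0.01 log units; within the scatter), nothing beyond the scatter. Compound 3 is therefore estimated at 7000 nM, with a range from 2500 nM to 20000 nM.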

Compound 3, concentration lethal to 50% of the cells: 38300 nM
The estimate for compound 3 lay 5.5-fold (0.74 log units) below the measured number; measured number outside the range, above it.
By their numbers in this assay, from the lowest: compounds 2 and 1 (each within the scatter of the next); then compound 3.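

In this assay, the 2-hydroxyphenyl and 2-chlorophenyl compounds stayed within the scatter of each other, so the earlier pair showed no clear response at this saturated ring carbon. For the compounds shown here, the 2-phenylethenyl group gives the first change beyond the scatter here: a 5.6-fold higher number from compound 2 to compound 3 (0.75 log units; beyond the scatter) and a 3.0-fold higher number from compound 1 to compound 3 (0.47 log units; beyond the scatter). No evidence on hand explains this result. As far as these compounds go, it remains open whether the shift follows the double bond or the added carbons, and what a 2-phenylethyl group would give at this position.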